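From Dimethylamino to Diethylamino on a Shared Core

This account rests on a few compounds, and the source may have more. Where it says the series, first, only, none or still open, it means among the compounds named here.

Compound 1 `COC/C1=C/C[C@](C)(CCC=C(C)C)/C=C/[C@@H](OC(=O)C=C(C)C)[C@](C)(O)/C=C/C1=O`: 11000 nM
Compound 2 `CC(C)=CCC[C@]1(C)/C=C/[C@@H](OC(=O)C=C(C)C)[C@](C)(O)/C=C/C(=O)/C(CN(C)C)=C\C1`: 820 nM

Both values come from a functional assay on SMMC-7721 cells (Homo sapiens) for antiproliferative activity, read by MTT assay, with a stated time of 48 h; a lower number here means a stronger inhibitor, a higher number a weaker inhibitor. Compound 2 is the stronger inhibitor of the two, at 820 nM. For the measured compounds named here, the one measured step is a 13-fold lower number from compound 1 to compound 2 (1.13 log units; beyond the scatter), and it comes from placing dimethylamino where methoxy stood on a saturated chain carbon bound to a double-bonded ring carbon.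

Compound 3 `CCN(CC)C/C1=C/C[C@](C)(CCC=C(C)C)/C=C/[C@@H](OC(=O)C=C(C)C)[C@](C)(O)/C=C/C1=O` changes the same place: diethylamino in place of dimethylamino on a saturated chain carbon bound to a double-bonded ring carbon. Here, diethylamino replaces dimethylamino. The step of a 13-fold lower number from compound 1 to compound 2 (1.13 log units; beyond the scatter) replaced methoxy rather than one amino group with another, so it sets no size for this change. Going by the values given here, no measured pair compares two amino groups. With so little to go on, no step beyond the scatter is expected, and the expected change is a 1.2-fold higher number from compound 2 to compound 3 (0.09 log units; within the scatter). For compound 3, the estimated value is 1000 nM, with an expected range of 300 nM to 3000 nM.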

Compound 3, half-maximal inhibitory concentration: 570 nM
The estimate for compound 3 lay 1.8-fold (0.24 log units) above the measured number; low and high end bracket the measured number.
By their numbers in this assay, from the lowest: compounds 3 and 2 (each within the scatter of the next); then compound 1.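

In this assay, putting diethylamino in place of dimethylamino on a saturated chain carbon bound to a double-bonded ring carbon gives a 1.4-fold lower number from compound 2 to compound 3 (0.16 log units; within the scatter) and so the two amino groups cannot be told apart here. Diethylamino in place of methoxy at the same place gives a 19-fold lower number from compound 1 to compound 3 (1.29 log units; beyond the scatter) and this shows that the large drop first seen with dimethylamino is not limited to that one amino group. Nothing measured here explains why either amino group differs from methoxy or why the two give such similar numbers.

On these data alone, it remains open whether an amino group with longer chains on its nitrogen would keep numbers like these. The same question stands for an amine closed into a ring, such as piperidine or morpholine.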